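The source may hold more compounds than are shown below. What is called first, only, known or untested is meant among the compounds shown, and "the series" means these compounds.

For the measured compounds named here, compound 1, `CC(=O)OC[C@H]1O[C@@H](Oc2nc(-c3cccs3)cc(-c3ccc(Cl)cc3)c2C#N)[C@H](OC(C)=O)[C@@H]1OC(C)=O`, is one of three compounds measured in a functional assay on MCF7 cells (Homo sapiens) for inhibition, read by MTT assay, with a stated time of 48 h, tested at 100 ug/mL; a higher number here means a stronger effect of the compound at the concentration tested, a lower number a weaker effect. In this assay compound 1 gives 12%, the second highest of the three numbers. Compound 2, `CC(=O)OC[C@H]1O[C@@H](Oc2nc(-c3cccs3)cc(-c3ccc(Cl)cc3)c2C#N)[C@H](OC(C)=O)[C@@H](OC(C)=O)[C@H]1OC(C)=O`, gives 20%, a number within the usual scatter of that of compound 1, while compound 3, `N#Cc1c(-c2ccc(Cl)cc2)cc(-c2cccs2)nc1O[C@@H]1O[C@H](CO)[C@@H](O)[C@H]1O`, gives 0%, a gap beyond the scatter. Compound 4, `CC(=O)OC[C@H]1O[C@@H](Oc2nc(-c3cccs3)cc(-c3ccc(Cl)cc3)c2C#N)[C@H](OC(C)=O)[C@H]1OC(C)=O`, has not been measured. It differs from compound 1 as follows: the two compounds have the same atoms and bonds and differ only in configuration as drawn: 1 of 4 stereo elements differ; a stereocentre at a saturated ring carbon is drawn R in compound 1 and S in compound 4. Going by the values given here, no step between measured compounds that differ in a single place is available, so there is no measured guide for a change in configuration alone. The expected step from compound 1 to compound 4 is no change at the digits printed from compound 1 to compound 4 (within the scatter), none beyond the scatter. Compound 4 is therefore estimated to give about 12% in this assay, with a range from 0% to 30%.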

Compound 4, a percentage reported as inhibition, at one concentration (the size of the read-out at that concentration, not a potency): 8%
Compound 4: middle estimate off by 4 percentage points, on the high side; low and high end bracket the measured number.
By their numbers in this assay, from the lowest: compounds 3, 4, 1 and 2 (each within the scatter of the next, the first and the last beyond it).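

In this assay, for the compounds shown here, this is the first measured change of configuration alone, and turning one saturated ring carbon from R to S gives a number 4 percentage points lower from compound 1 to compound 4 (within the scatter). At this stereocentre, the drawn configuration therefore makes no difference beyond the scatter at the single concentration tested. The comparison isolates this one stereocentre: the fact that compounds 1 and 4 differ only in the configuration as drawn.

The compounds shown leave open whether changing the configuration at the other stereocentres would give the same result. They also leave open whether an amine or a carboxylic acid on the shared core would change the read-out.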